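Removing the fluoro from compound 3: no shift expected

The compounds below may be only part of what the source reports. "The series", "measured", "known", "first", "only" and "open" are said of these compounds alone.

Compound 3 `OC[C@@]1(c2cccc(F)c2)NC[C@@H](O)[C@@H]1O` gives 0% in an assay on isolated protein for inhibition of alpha-mannosidase (Canavalia ensiformis), tested at 1000 uM (a higher number here means more inhibition at the concentration tested (going by the name of the read-out), a lower number less inhibition), level at the digits shown with compound 2 `Cc1ccc([C@]2(CO)NC[C@@H](O)[C@@H]2O)cc1`, which gives 0% in this assay; the two stand together as the lowest of the three measured numbers. Compound 1 `OC[C@@]1(c2ccc(F)cc2)NC[C@@H](O)[C@@H]1O` gives 6.6% in this assay, and the gap from compound 3 to it lies within the scatter. Compound 4 `OC[C@@]1(c2ccccc2)NC[C@@H](O)[C@@H]1O` differs from compound 3 by hydrogen in place of fluoro on an aromatic carbon. For the measured compounds named here, the only measured step, a number 6.6 percentage points lower from compound 1 to compound 2 (within the scatter), alters a group on the same aromatic ring and stays within the scatter. Going by the values given here, no measured step covers fluoro to hydrogen directly, so compound 4 is expected to stay flat, with a number 2 percentage points higher from compound 3 to compound 4 (within the scatter) amounting to nothing beyond the scatter. Compound 4 is estimated at 2%, in the range 0% to 12%.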

Compound 4, a percentage reported as inhibition, at one concentration (the size of the read-out at that concentration, not a potency): 0%
Compound 4: middle estimate off by 2 percentage points, on the high side; the range from low to high includes it.
By their numbers in this assay, from the lowest: compounds 2, 3, 4 and 1 (each within the scatter of the next).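

In this assay, for the compounds shown here, hydrogen in place of fluoro on the aromatic carbon gives no change at the digits printed from compound 3 to compound 4 (within the scatter), the first direct reading of this change at this position. Hydrogen in place of methyl gives no change at the digits printed from compound 2 to compound 4 (within the scatter), and hydrogen in place of the fluoro of compound 1 gives a number 6.6 percentage points lower from compound 1 to compound 4 (within the scatter), so neither fluoro nor methyl separates from hydrogen on this ring. Nothing available offers an explanation for this flat result. From the compounds shown here alone, whether an amine or a carboxylic acid on this ring would lift the number beyond the scatter remains open.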